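The source may report more compounds than this note shows. Statements on the series, on what has been measured and on what is new or still open speak of the compounds shown alone.

Measured so far:

Compound 1, `C[n+]1ccn(CCCC#N)c1/C=N/O` — in a physicochemical assay for lipophilicity (on this read-out lower numbers stand for lower lipophilicity and higher numbers for higher lipophilicity), compound 1 gives < -3.
Compound 2, `C[n+]1ccn(COCCCCCl)c1/C=N/O` — in this assay compound 2 gives -1.47.

Among the compounds with values here, compound 2 is the only compound of the two with an actual number in this assay. For compound 1 the read-out of < -3 is a limit of the assay and not a number, so compound 1 marks (the limit of < -3 in this assay, at which 1 of the 2 values shown sits). Compound 2 therefore stands on its own as the single measured reference point.

Compound 3, `C[n+]1ccn(COCCCBr)c1/C=N/O`, has not yet been measured in this assay. It differs from compound 2 in one place: bromo in place of chloromethyl on a saturated chain carbon, three bonds along the chain from an oxygen on a saturated carbon. Put simply, the chain is cut short by one carbon and ends in bromine instead of chlorine, while the rest of the molecule, including the charged core and the oxime on it, is unchanged.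

Within the data shown here, no measured pair in this set shows what such a change does in this assay. As an expectation only, the step from compound 2 to compound 3 is estimated to be small and downward, a number 0.33 log units lower from compound 2 to compound 3 (beyond the scatter), close to the usual scatter. Compound 3 is accordingly expected to give about -1.8, most likely between -2.4 and -1.2.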

Compound 3, distribution coefficient: -1.76
The estimate for compound 3 lay 0.04 log units below the measured number, within the range that was stated.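

Putting bromo in place of chloromethyl, on a saturated chain carbon three bonds along the chain from an oxygen on a saturated carbon, gives a number 0.29 log units lower from compound 2 to compound 3 (within the scatter), so in this assay the two compounds cannot be told apart, and this end of the chain tolerates this particular swap without a measurable difference. The other comparison concerns the whole side chain on a saturated chain carbon bound to an aromatic nitrogen, where 3-bromopropoxy stands in place of 2-cyanoethyl, and it gives a number at least 1.24 log units higher from compound 1 to compound 3 (beyond the scatter), the first clear gap in this small set. The read-out of compound 1 is a limit of the assay and not a number, so this gap has a floor but no exact size: the limit of < -3 in this assay, at which 1 of the 3 values shown sits.

From the compounds shown here alone, the swap from compound 2 to compound 3 alters the halogen and the chain length in a single move, so the contribution of each one alone remains unknown. Also open, going by these compounds, is what this read-out would do with a different group at the end of the chain, such as an amine or a carboxylic acid, or with a longer chain ending in bromine.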